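A few compounds are considered here, and "the series" means these few. Any claim that something is new, unique, unknown or untested is made for them only; others in the source may bear on it.

Measured compounds:
Compound 1, `S=C(Nc1ccccc1)N1N=C(c2ccc(Cl)cc2)CC1c1ccc2c(c1)OCCO2`: 195000 nM
Compound 2, `CSc1ccc(C2=NN(C(=S)Nc3ccccc3)C(c3ccc4c(c3)OCCO4)C2)cc1`: 159000 nM

In a functional assay on A-375 cells (Homo sapiens) for antiproliferative activity, read by MTT assay, with a stated time of 48 h (a higher number here means a weaker inhibitor of growth, a lower number a stronger inhibitor of growth), compound 2 gives 159000 nM, while compound 1 gives 195000 nM. Compound 2 stands alongside compound 1 rather than apart from it: the step of a 1.2-fold lower number from compound 1 to compound 2 (0.09 log units; within the scatter) lies within the scatter, so the two compounds are not told apart by these numbers.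

Compound 3, `S=C(Nc1ccccc1)N1N=C(c2cccc(Cl)c2)CC1c1ccc2c(c1)OCCO2`, differs from compound 2 by 3-chlorophenyl in place of 4-(methylsulfanyl)phenyl on a carbon with a double bond to nitrogen. Within the data shown here, the only measured step, a 1.2-fold lower number from compound 1 to compound 2 (0.09 log units; within the scatter), exchanges one substituent for another on the same ring and produced no change beyond the scatter; it bears on the present change only loosely, as no measured pair moves the chloro from one ring position to another. Compound 3 is therefore expected to land close to its two neighbours, a 1.1-fold higher number from compound 2 to compound 3 (0.05 log units; within the scatter). The value of compound 3 is estimated at 180000 nM, within a range of 70000 nM to 450000 nM.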

Compound 3, concentration for 50% growth inhibition: > 200000 nM
Compound 3 gave a limit, no number; the forecaster's own chance of this, stated with the estimate: 15%; middle value at least 1.1-fold (0.04 log units) away from the limit.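

In this assay compound 3 gives > 200000 nM, which is a limit of the assay and not a number: the limit of > 200000 nM in this assay, at which 1 of the 3 values shown sits.

Among these compounds, this is the first view of the chloro group on a different ring position: going from 4-chlorophenyl to 3-chlorophenyl gives an at least 1.0-fold higher number from compound 1 to compound 3 (0.01 log units; that floor lies within the scatter), so the floor does not separate the two compounds, and the true size of the step remains unknown. Among the compounds shown here, the exchange of 4-(methylsulfanyl)phenyl for 3-chlorophenyl gives an at least 1.2-fold higher number from compound 2 to compound 3 (0.09 log units; that floor lies within the scatter), so no step at this position is yet printed beyond the scatter, although for compound 3 the upper side has no bound.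

As far as these compounds go, whether compound 3 truly differs from compound 1 or compound 2 stays open. From the compounds shown here alone, how an amine, a carboxylic acid or a longer chain on this phenyl ring would read in this assay also remains open.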